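This account rests on a few compounds, and the source may have more. Where it says the series, first, only, none or still open, it means among the compounds named here.

In a functional assay on BGC-823 cells (Homo sapiens) for antiproliferative activity, read by MTT assay, with a stated time of 48 h (on this read-out lower numbers stand for stronger inhibition and higher numbers for weaker inhibition), compound 1 (`O=[N+]([O-])c1cccc(CSc2nnc(-c3ccc4c(c3)OCCO4)o2)c1`) gives 23700 nM in these notes, compound 2 (`Brc1ccccc1CSc1nnc(-c2ccc3c(c2)OCCO3)o1`) gives 21200 nM and compound 3 (`Clc1ccc(CSc2nnc(-c3ccc4c(c3)OCCO4)o2)cc1`) gives 22600 nM on the same read-out. Compound 2 lies within the scatter of both other compounds, so the three values form one flat group and compound 2 holds no distinct place in it.

The next compound to read is compound 4 (`Clc1ccccc1CSc1nnc(-c2ccc3c(c2)OCCO3)o1`). The structural change is chloro in place of bromo on an aromatic carbon with chloro in place of bromo on an aromatic carbon, ortho to a large group.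

For the measured compounds named here, one measured step bears on this change: a 1.1-fold higher number from compound 2 to compound 3 (0.03 log units; within the scatter) with 4-chlorophenyl in place of 2-bromophenyl on a saturated chain carbon bound to a sulfur. Going by the values given here, that step also replaces bromo with chloro, but the place of the halogen differs as well, and no measured pair isolates the exchange at one place. It remains the closest evidence, and it is small.

A step beyond the scatter is therefore not expected in this assay for this exchange. The expected step of a 1.0-fold higher number from compound 2 to compound 4 (0.02 log units; within the scatter) stays inside the scatter, with no direction favoured. For compound 4 the estimated value is 22000 nM with an expected range from 12000 nM to 38000 nM as the working figure.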

Compound 4, half-maximal inhibitory concentration: 22500 nM
Compound 4: the middle estimate sits 1.0-fold (0.01 log units) below what was measured, within the range that was stated.
By their numbers in this assay, from the lowest: compounds 2, 4, 3 and 1 (each within the scatter of the next).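

In this assay the exchange of halogen is now isolated at one place: chloro in place of bromo on an aromatic carbon, ortho to a large group, gives a 1.1-fold higher number from compound 2 to compound 4 (0.03 log units; within the scatter), so at this position the two halogens cannot be told apart, whereas the earlier step changed the halogen and its place together. The place of the chloro can now also be read alone: 2-chlorophenyl in place of 4-chlorophenyl on a saturated chain carbon bound to a sulfur gives a 1.0-fold lower number from compound 3 to compound 4 (0.00 log units; within the scatter), and this step too stays within the scatter, so the halogen and its place each leave the number flat across these compounds. No measurement at hand offers an explanation for this flatness.

The compounds shown carry only a halogen or a nitro group on the benzyl ring, so it remains open whether an amine or a carboxylic acid on that ring would leave the number equally flat. Also open, from the compounds shown here alone, is whether a longer chain between the sulfur and that ring, or any change to the shared core, would produce a step beyond the scatter.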